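Removing the acetyl group from compound 3

The compounds below may be only part of what the source reports. "The series", "measured", "known", "first", "only" and "open" are said of these compounds alone.

Measured in an ADME assay on MT4 cells (Homo sapiens) for cytotoxicity, read by MTT assay, with a stated time of 4 days; on this read-out lower numbers stand for higher toxicity in this test and higher numbers for lower toxicity in this test:
- compound 1 `CC(=O)Nc1ccc2oc(-c3ccccc3)cc(=O)c2c1` gives 184000 nM
- compound 2 `CC(=O)Nc1ccc2oc(-c3ccccc3F)cc(=O)c2c1` gives 205000 nM
- compound 3 `CC(=O)Nc1ccc2oc(-c3cccc(F)c3)cc(=O)c2c1` gives 240000 nM

Compound 3 is not separated from the other two (a 1.2-fold higher number from compound 2 to compound 3 (0.07 log units; within the scatter) and a 1.3-fold higher number from compound 1 to compound 3 (0.12 log units; within the scatter)). Compound 4 `Nc1ccc2oc(-c3cccc(F)c3)cc(=O)c2c1` carries hydrogen in place of acetyl on a nitrogen on an aromatic ring, which turns acetamido to amino (hydrogen in place of acetyl on a nitrogen on an aromatic ring). Among the measured compounds shown here, the only steps measured so far are fluoro changes on an aromatic carbon, such as a 1.1-fold higher number from compound 1 to compound 2 (0.05 log units; within the scatter), and none of them touches this nitrogen. For the measured compounds named here, they therefore give no direct guide to size, and no measured compound lacks the acetyl. In this assay a modest move to a lower number is expected, with wide uncertainty. The expected change is a 2.0-fold lower number from compound 3 to compound 4 (0.30 log units; within the scatter). For compound 4 the estimated value is 120000 nM, with an expected range from 35000 nM to 300000 nM.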

Compound 4, half-maximal cytotoxic concentration: 269000 nM
For compound 4 the middle estimate is 2.2-fold (0.35 log units) below the measured one; low and high end bracket the measured number.
By their numbers in this assay, from the lowest: compounds 1, 2, 3 and 4 (each within the scatter of the next).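

Among the compounds shown here, with the 3-fluorophenyl group held constant, the acetamido to amino change gives the first reading at this nitrogen on an aromatic ring, and in this assay the step stays within the scatter (a 1.1-fold higher number from compound 3 to compound 4 (0.05 log units; within the scatter)). Losing the acetyl, with its 3 heavy atoms, therefore has no readable effect on this read-out in this pair, just as the fluoro changes had none in theirs. Nothing available explains why the number holds here.

From the compounds shown here alone, whether a longer acyl chain, a methylsulfonyl group or a dimethylamino group on this nitrogen would also stay within the scatter remains open. So does whether the amino group would behave alike with the 2-fluorophenyl group or the unsubstituted phenyl group.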